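The compounds below may be only part of what the source reports. "The series", "measured", "known", "first", "only" and "open" are said of these compounds alone.

Compound 3 `O=C(/N=C(/NCc1ccccc1)Nc1ccc(F)cc1)c1ccccc1` gives 866000 nM in an ADME assay on cells (Peritoneal macrophage, Mus musculus) for cytotoxicity, read by MTT assay, with a stated time of 24 h (a higher number here means that more compound is tolerated, a lower number that less compound is tolerated), which places it second highest among the three compounds measured. Its nearest neighbour is compound 2 `COc1ccc(N/C(=N\C(=O)c2ccccc2)NCc2ccccc2)cc1` with 837000 nM, and the furthest is compound 1 `CC(C)(C)c1ccc(N/C(=N\C(=O)c2ccccc2)NCc2ccccc2)cc1` with 1120000 nM. Compound 4 `O=C(/N=C(/NCc1ccccc1)Nc1ccc(Cl)cc1)c1ccccc1` has not yet been measured; it differs from compound 3 in one place: chloro in place of fluoro on an aromatic carbon. For the measured compounds named here, the steps that bear on this change are those that also swap the group at the same aromatic carbon: a 1.3-fold lower number from compound 1 to compound 3 (0.11 log units; within the scatter) and a 1.0-fold higher number from compound 2 to compound 3 (0.01 log units; within the scatter), both within the scatter, as is a 1.3-fold lower number from compound 1 to compound 2 (0.13 log units; within the scatter). Since all three swaps at that carbon left the number essentially unchanged, no step beyond the scatter is expected in this assay. Compound 4 is therefore expected to give about 850000 nM, between 500000 nM and 1400000 nM, a step of a 1.0-fold lower number from compound 3 to compound 4 (0.01 log units; within the scatter).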

Compound 4, half-maximal cytotoxic concentration: 827000 nM
Beside the measured number, compound 4's estimate is 1.0-fold (0.01 log units) above it; the range from low to high includes it.
By their numbers in this assay, from the lowest: compounds 4, 2, 3 and 1 (each within the scatter of the next).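

In this assay, chloro joins tert-butyl, methoxy and fluoro at this aromatic carbon, and every swap to it stays within the scatter (a 1.0-fold lower number from compound 3 to compound 4 (0.02 log units; within the scatter); a 1.0-fold lower number from compound 2 to compound 4 (0.01 log units; within the scatter); a 1.4-fold lower number from compound 1 to compound 4 (0.13 log units; within the scatter)). The earlier compounds shown here held no swap of one halogen for another, and this one leaves the tolerated concentration unchanged as well. Nothing available explains this flat result. The compounds shown leave open whether an amine or a carboxylic acid at this carbon would also leave the number unchanged. They also leave open whether changes elsewhere on the shared core would.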